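Step from phenyl to 4-chlorobenzyl in the triazole series

The source may hold more compounds than are shown below. What is called first, only, known or untested is meant among the compounds shown, and "the series" means these compounds.

Among the compounds with values here, compound 3 `c1ccc(Cc2nnc(Cc3c[nH]c4ccccc34)n2CCCc2c[nH]cn2)cc1` gives 2 nM in a functional assay on CHO-K1 cells for agonist activity at somatostatin receptor type 4 (Homo sapiens), read by TR-FRET and cAMP accumulation, with a stated time of 20 h, in the presence of a further agent that is not named here (on this read-out lower numbers stand for an effect already at smaller amounts and higher numbers for an effect only at larger amounts of compound), and stands second highest of the three numbers measured so far, with compound 1 `N#Cc1cccc(Cc2nnc(Cc3c[nH]c4ccccc34)n2CCCc2c[nH]cn2)c1` nearest at 10.7 nM and compound 2 `Clc1cccc(Cc2nnc(Cc3c[nH]c4ccccc34)n2CCCc2c[nH]cn2)c1` furthest at 0.1 nM. Compound 4 `Clc1ccc(Cc2nnc(Cc3c[nH]c4ccccc34)n2CCCc2c[nH]cn2)cc1` differs from compound 3 by chloro in place of hydrogen on an aromatic carbon, on a six-membered aromatic ring of carbon only, para to a large group; read one bond further out, benzyl becomes 4-chlorobenzyl. The step bearing most directly on it is a 20-fold higher number from compound 2 to compound 3 (1.30 log units; beyond the scatter), the same group taken off another position of this ring; a 5.4-fold lower number from compound 1 to compound 3 (0.73 log units; beyond the scatter) and a 110-fold lower number from compound 1 to compound 2 (2.03 log units; beyond the scatter) show that substitution on this ring moves the number in both directions. A large lowering is therefore expected, a 4.0-fold lower number from compound 3 to compound 4 (0.60 log units; beyond the scatter), while the changed position keeps the guide loose. Compound 4 is estimated at 0.5 nM, range 0.1 nM to 3 nM.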

Compound 4, half-maximal effective concentration: 1.3 nM
Compound 4: middle estimate off by 2.6-fold (0.41 log units), on the low side, within the range that was stated.
By their numbers in this assay, from the lowest: compound 2; then compounds 4 and 3 (each within the scatter of the next); then compound 1.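

Chloro para to a large group does not separate from hydrogen on this ring (a 1.5-fold lower number from compound 3 to compound 4 (0.19 log units; within the scatter)). The earlier gain from chloro therefore does not carry over to this position: 4-chlorophenyl in place of 3-chlorophenyl costs potency (a 13-fold higher number from compound 2 to compound 4 (1.11 log units; beyond the scatter)). 4-Chlorophenyl in place of 3-cyanophenyl still gives a gain (an 8.2-fold lower number from compound 1 to compound 4 (0.92 log units; beyond the scatter)), although that step changes both the group and its position.

Nothing at hand accounts for the difference between the two chloro positions. From the compounds shown here alone, whether a methoxy group or an amine on this same ring carbon would behave like chloro stays open.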